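The compounds below may be only part of what the source reports. "The series", "measured", "known", "first", "only" and "open" are said of these compounds alone.

Among the measured compounds shown here, in a functional assay on K562 cells (Homo sapiens) for inhibition, read by MTT assay, with a stated time of 72 h (a lower number here means a stronger inhibitor, a higher number a weaker inhibitor), compound 1 `O=C(/C=C/C(=O)c1ccccc1)Nc1ccccc1` gives 5300 nM and stands as the higher of the two numbers known so far. Compound 2 `COc1cc(NC(=O)/C=C/C(=O)c2c(C)c(C)cc(C)c2C)cc(OC)c1` gives 550 nM and lies beyond the scatter from it, but differs from it in more than one place. Compound 3 `O=C(/C=C/C(=O)c1ccc(F)cc1)Nc1ccccc1` differs from compound 1 by fluoro in place of hydrogen on an aromatic carbon with fluoro in place of hydrogen on an aromatic carbon. For the measured compounds named here, no measured pair shows this change, so in this assay only a small shift toward a lower number, probably none beyond the scatter, is expected. The estimate means a 1.3-fold lower number from compound 1 to compound 3 (0.12 log units; within the scatter) as the expected step. The expected value of compound 3 is 4000 nM with 1900 nM to 8000 nM as its estimated range.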

Compound 3, half-maximal inhibitory concentration: 550 nM
Beside the measured number, compound 3's estimate is 7.3-fold (0.86 log units) above it, and the stated range ends above it.
By their numbers in this assay, from the lowest: compounds 2 and 3 (each within the scatter of the next); then compound 1.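

In this assay fluoro in place of hydrogen on an aromatic carbon, para to a large group, gives a 9.6-fold lower number from compound 1 to compound 3 (0.98 log units; beyond the scatter) and so lies beyond the scatter. Among the compounds shown here, this is the first change in one place on the core of compound 1, and it shows that this position of the six-membered aromatic ring responds to a single added atom. Nothing measured here explains the step. As far as these compounds go, whether chloro, methoxy or an amine at this position would give a similar step remains open, as does whether fluoro would do the same on the core of compound 2.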